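The source may report more compounds than this note shows. Statements on the series, on what has been measured and on what is new or still open speak of the compounds shown alone.

The shared core of compound 1 (`CC1C(=O)c2nc(CN3N=C(Cl)CCC3=O)[nH]c2N(C)C1=O`) carries a chloro group on a carbon with a double bond to nitrogen of the six-membered non-aromatic ring with two nitrogens. In an assay on isolated protein for binding affinity to adenosine receptor A1 (Homo sapiens) (a lower number here means a stronger inhibitor, a higher number a weaker inhibitor), compound 1 gives > 100000 nM, which is a limit of the assay and not a number (the limit of > 100000 nM in this assay, at which 1 of the 3 values shown sits). Two relatives with a longer chain between the core and that ring have been measured: compound 2 (`CC1C(=O)c2nc(CCCN3N=C(Cl)CCC3=O)[nH]c2N(C)C1=O`) gives 8800 nM in this assay, and compound 3 (`CC1C(=O)c2nc(CCCCN3N=C(Cl)CCC3=O)[nH]c2N(C)C1=O`) gives 370 nM in this assay. Compound 4 (`CC1C(=O)c2nc(CN3N=C(c4ccccc4)CCC3=O)[nH]c2N(C)C1=O`) keeps the short chain of compound 1 and differs from it by phenyl in place of chloro on a carbon with a double bond to nitrogen, in words phenyl in place of chloro on a carbon with a double bond to nitrogen. Within the data shown here, no measured pair shows what this exchange does. The expectation for compound 4 is a modest gain, a step of an at least 1.6-fold lower number from compound 1 to compound 4 (0.22 log units; that floor lies within the scatter) that may still leave only a limit. The estimate for compound 4 in this assay is 60000 nM, in a range from 10000 nM to 300000 nM.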

Compound 4, inhibition constant: 53800 nM
The estimate for compound 4 lay 1.1-fold (0.05 log units) above the measured number; measured number inside the range.
By their numbers in this assay, from the lowest: compound 3; then compound 2; then compound 4. At a limit, above all of these: compound 1.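

In this assay compound 1 gives > 100000 nM, which is a limit of the assay and not a number. Phenyl in place of chloro on a carbon with a double bond to nitrogen gives an at least 1.8-fold lower number from compound 1 to compound 4 (0.26 log units; that floor lies within the scatter), so compound 4 is the first compound shown with the short chain that has a readable number, and the larger group at this position does not push binding out of the measurable range. The true size of this step stays unknown, and its floor alone does not establish a gain, because one end of the step is a limit: the limit of > 100000 nM in this assay, at which 1 of the 4 values shown sits.

On these data alone, what phenyl does on the longer chains of compound 2 and compound 3 remains open. Also open, as far as these compounds go, is how a methoxy group or an amine at this position would compare with phenyl.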